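This account rests on a few compounds, and the source may have more. Where it says the series, first, only, none or still open, it means among the compounds named here.

Working notes on the series. For the measured compounds named here, compound 1 `CCCC[C@H](NC(=O)O[C@H](Cn1cnc(-c2ccc(C(F)(F)F)cc2)c1)C(C)(C)C)C(=O)C(=O)Nc1ccn[nH]1` and compound 2 `CCCC[C@H](NC(=O)O[C@H](Cn1ccc(-c2ccc(C(F)(F)F)cc2)n1)C(C)(C)C)C(=O)C(=O)Nc1ccccn1` are the two compounds measured so far in an in vivo ADME assay on the whole organism (Rattus norvegicus) for pharmacokinetics; on this read-out higher numbers stand for higher oral bioavailability and lower numbers for lower oral bioavailability. In this assay compound 1 gives 55%. In this assay compound 2 gives 34%, the lower of the two numbers, and the gap to compound 1 lies beyond the scatter. Going by the values given here, the two structures differ in more than one place, so no single step connects them and the gap cannot be tied to any one change.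

Compound 3 `CCCC[C@H](NC(=O)O[C@H](Cn1ccc(-c2ccc(C(F)(F)F)cc2)n1)C(C)(C)C)C(=O)C(=O)NCc1ccno1` has not yet been measured in this assay. It follows from compound 2 by one change: (1,2-oxazol-5-yl)methyl in place of pyridin-2-yl on an amide-type nitrogen. Among the compounds with values here, no measured pair isolates a change of this kind, so nothing in the data fixes the size or the direction of the step. The step from compound 2 to compound 3 in this assay is therefore expected to be a number 4 percentage points lower from compound 2 to compound 3 (within the scatter), that is, none beyond the scatter. For compound 3 in this assay the estimate is 30%, with a range from 12% to 55%. The range is kept wide since compound 2 at 34% is the only anchor for it.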

Compound 3, oral bioavailability: 40%
Compound 3: middle estimate off by 10 percentage points, on the low side, within the range that was stated.
By their numbers in this assay, from the lowest: compounds 2 and 3 (each within the scatter of the next); then compound 1.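

In this assay the amide-type nitrogen now has its first single-place step, a number 6 percentage points higher from compound 2 to compound 3 (within the scatter), with (1,2-oxazol-5-yl)methyl in place of pyridin-2-yl. At this position, then, one six-membered aromatic ring with 1 hetero atom and one five-membered aromatic ring with 2 hetero atoms carried on a methyl link, both groups of 6 heavy atoms, give numbers that the usual scatter does not separate, so this exchange is tolerated on the core of compound 2 without a readable change. Nothing measured on the compounds accounts for this result.

The compounds shown do not separate the methyl link from the change of ring, as a pyridin-2-ylmethyl or a plain benzyl group on the amide-type nitrogen would. As far as these compounds go, what a group bearing an amine or a carboxylic acid would do at this nitrogen, and how the group that compound 1 carries there would read on the core of compound 2, also stay open.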